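The compounds below may be only part of what the source reports. "The series", "measured", "known", "first", "only" and "open" are said of these compounds alone.

Measured so far in an ADME assay on KB cells (Homo sapiens) for cytotoxicity; a lower number here means that less compound is needed, a higher number that more compound is needed for the effect:
Compound 1 `CCCOc1c(OC)c(OC)cc2c1C(=O)[C@]1(OC)C=C[C@H]2N(C(=O)OCC)N1C(=O)OCC` gives > 300 ug/mL, which is a limit of the assay rather than a number.
Compound 2 `CCOC(=O)N1[C@@H]2C=C[C@@](OC)(C(=O)c3c2cc(OC)c(OC)c3OCc2ccc(Cl)cc2)N1C(=O)OCC` gives 99.9 ug/mL.
Compound 3 `CCCOc1c(OC)c(OC)cc2c1C(=O)[C@]1(OC)C=C[C@H]2N(C(=O)OCC(C)C)N1C(=O)OCC(C)C` gives 299 ug/mL.

Compound 1 and compound 2 share one core and differ in a single place: 4-chlorophenyl in place of ethyl on a saturated chain carbon bound to an oxygen on an aromatic ring. That change brought an at least 3.0-fold lower number from compound 1 to compound 2 (0.47 log units; beyond the scatter); the step is known only as a bound because the limit of > 300 ug/mL in this assay, at which 1 of the 3 values shown sits, is all that compound 1 shows. Compound 3 carries a different core; how its core differs from that of compound 1 is not broken down here. Among the two plain numbers, compound 3 stands highest, with compound 2 nearest to it.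

Compound 4 `COc1cc2c(c(OCc3ccc(Cl)cc3)c1OC)C(=O)[C@]1(OC)C=C[C@H]2N(C(=O)OCC(C)C)N1C(=O)OCC(C)C` has not yet been measured. It differs from compound 3 by the same change that turned compound 1 into compound 2: 4-chlorophenyl in place of ethyl on a saturated chain carbon bound to an oxygen on an aromatic ring. Since that change brought an at least 3.0-fold lower number from compound 1 to compound 2 (0.47 log units; beyond the scatter) on the other core, a step of similar size is expected here, a 3.0-fold lower number from compound 3 to compound 4 (0.48 log units; beyond the scatter). Compound 4 is therefore estimated at 100 ug/mL in this assay, most likely between 40 ug/mL and 250 ug/mL.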

Compound 4, concentration for half-maximal effect: 42 ug/mL
Compound 4: the middle estimate sits 2.4-fold (0.38 log units) above what was measured, and the stated range covers the measured number.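

In this assay, putting (4-chlorobenzyl)oxy in place of propoxy brought a 7.1-fold lower number from compound 3 to compound 4 (0.85 log units; beyond the scatter), so on this second core too, less compound is needed for the effect once the change is made. Set beside the earlier step, the direction agrees on both cores, but whether the size of the step carries over remains unsettled: the same change on two cores in this assay, an at least 3.0-fold lower number (0.47 log units; beyond the scatter) from compound 1 to compound 2 and a 7.1-fold lower number (0.85 log units; beyond the scatter) from compound 3 to compound 4; the limit leaves it open whether they differ Compound 1 gives > 300 ug/mL, which is a limit and not a number, and two cores alone do not show that the change would act the same way on any further core.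

The compounds shown leave open whether the lower number goes with the aromatic ring itself or with its chlorine, as only 4-chlorobenzyl stands against propyl here, and a plain benzyl would separate the two. They also leave open how a longer chain such as hexyl, or a group carrying an amine or a carboxylic acid, would read in this assay at this place.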